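The compounds below may be only part of what the source reports. "The series", "measured", "known", "first", "only" and "open" are said of these compounds alone.

Compound 1 `COc1ccc(-c2nnc(NC(=O)/C=C/c3ccc(F)cc3)s2)cc1` gives 0.75 ug/mL
Compound 2 `O=C(/C=C/c1ccccc1)Nc1nnc(-c2ccccc2)s1` gives 1.75 ug/mL
Compound 3 `O=C(/C=C/c1ccc(F)cc1)Nc1nnc(-c2ccc(Br)cc2)s1` gives 2.83 ug/mL

In a functional assay on A549 cells (Homo sapiens) for antiproliferative activity, read by MTT assay, with a stated time of 48 h (a higher number here means a weaker inhibitor, a lower number a stronger inhibitor), the value of compound 3 lies within the usual scatter of the value of compound 2. The step of a 3.8-fold higher number from compound 1 to compound 3 (0.58 log units; beyond the scatter) is modest but beyond the scatter. Compound 4 `O=C(/C=C/c1ccccc1)Nc1nnc(-c2ccc(Br)cc2)s1` is the next to consider. The change is hydrogen in place of fluoro on an aromatic carbon and turns 4-fluorophenyl into phenyl, with hydrogen in place of fluoro on an aromatic carbon. Among the measured compounds shown here, no measured pair isolates this swap. For the measured compounds named here, the one measured step, bromo in place of methoxy, is a different change at a different place, so it offers only a sense of how far a single swap can move the number. Compound 2 has no fluoro, and its value of 1.75 ug/mL stays within the scatter of compound 3. No shift beyond the scatter is therefore expected, in either direction. The expected change is a 1.1-fold lower number from compound 3 to compound 4 (0.05 log units; within the scatter) and would be too small to read as real. Compound 4 is estimated at 2.5 ug/mL with a likely range of 1.2 ug/mL to 5.2 ug/mL for its measured value.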

Compound 4, half-maximal inhibitory concentration: 2.18 ug/mL
For compound 4 the middle estimate is 1.1-fold (0.06 log units) above the measured one; the range from low to high includes it.
By their numbers in this assay, from the lowest: compound 1; then compounds 2, 4 and 3 (each within the scatter of the next).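

In this assay, among the compounds shown here, hydrogen in place of fluoro on the 4-fluorophenyl group gives a 1.3-fold lower number from compound 3 to compound 4 (0.11 log units; within the scatter) and so leaves the two compounds indistinguishable, which is the first direct reading of this swap with the rest of the molecule held fixed. The new compound also isolates bromo in place of hydrogen on an aromatic carbon, which gives a 1.2-fold higher number from compound 2 to compound 4 (0.10 log units; within the scatter) and so also cannot be told apart from repeat-measurement scatter. Nothing measured here explains these small differences.

The compounds shown leave open whether the methoxy group would still give a lower number than bromo without the fluoro. They also leave open whether a larger replacement for the fluoro, such as an amine or a carboxylic acid, would move the number beyond the scatter.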